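The compounds below may be only part of what the source reports. "The series", "measured", "known", "first", "only" and "open" are said of these compounds alone.

The series shares one core and varies the group on an aromatic carbon of a six-membered aromatic ring. Compound 1 `CCC(C)(C)Cc1c[nH]c(CCc2ccc(N3CCCCC3)cc2)n1` gives 28 nM in a functional assay on HEK293 cells for agonist activity at Bombesin receptor subtype-3 (Mus musculus), read by luminescence and calcium flux, with a stated time of 10 min; a higher number here means that more compound is needed for the effect, a lower number that less compound is needed. Compound 2 `CCC(C)(C)Cc1c[nH]c(CCc2ccc(-n3ccnn3)cc2)n1`, carrying 1H-1,2,3-triazol-1-yl in place of piperidin-1-yl, gives 57 nM in this assay, the step being a 2.0-fold higher number from compound 1 to compound 2 (0.31 log units; beyond the scatter). Compound 3 `CCC(C)(C)Cc1c[nH]c(CCc2ccc(-c3ccns3)cc2)n1` gives 3.1 nM in this assay, the lowest number of the three; it is reached by a 9.0-fold lower number from compound 1 to compound 3 (0.96 log units; beyond the scatter) and by an 18-fold lower number from compound 2 to compound 3 (1.26 log units; beyond the scatter). Compound 4 `CCC(C)(C)Cc1c[nH]c(CCc2ccc(-n3cncn3)cc2)n1` is not yet measured and differs from compound 3 in one place: 1H-1,2,4-triazol-1-yl in place of 1,2-thiazol-5-yl on an aromatic carbon. The step that bears most directly on this change is an 18-fold lower number from compound 2 to compound 3 (1.26 log units; beyond the scatter), since compound 2 also carries a triazol-1-yl group, though of a different pattern; read backwards, it indicates that moving from 1,2-thiazol-5-yl to such a ring brings a large step upward. Compound 1 with its piperidin-1-yl sits in between the two. The expected step is therefore a 13-fold higher number from compound 3 to compound 4 (1.11 log units; beyond the scatter), an increase of about the size seen between compound 2 and compound 3. Compound 4 is thus estimated at 40 nM in this assay, with a range from 12 nM to 130 nM.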

Compound 4, half-maximal effective concentration: 12 nM
Beside the measured number, compound 4's estimate is 3.3-fold (0.52 log units) above it; low and high end bracket the measured number.
By their numbers in this assay, from the lowest: compound 3; then compound 4; then compound 1; then compound 2.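

In this assay, the two triazol-1-yl groups do not act as one kind of substituent: going from the 1H-1,2,3-triazol-1-yl of compound 2 to the 1H-1,2,4-triazol-1-yl of compound 4 gives a 4.8-fold lower number from compound 2 to compound 4 (0.68 log units; beyond the scatter), so on this aromatic carbon the arrangement of the ring nitrogens alone moves the number. Replacing the 1,2-thiazol-5-yl still raises the number (a 3.9-fold higher number from compound 3 to compound 4 (0.59 log units; beyond the scatter)), yet the 1H-1,2,4-triazol-1-yl also improves on piperidin-1-yl (a 2.3-fold lower number from compound 1 to compound 4 (0.37 log units; beyond the scatter)), which shows that a triazol-1-yl group can lie on either side of piperidin-1-yl, with compound 2 above it and compound 4 below it. No measurement shown here accounts for these differences between the rings.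

The compounds shown leave open whether a 1H-pyrazol-1-yl or a pyridinyl ring at this place would come closer to the 1,2-thiazol-5-yl of compound 3 than the triazol-1-yl groups do. They also leave open how a carboxylic acid or a simple open-chain amide would fare here, since every group shown is a single ring.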